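The source may hold more compounds than are shown below. What is called first, only, known or untested is meant among the compounds shown, and "the series" means these compounds.

In a functional assay on MGC-803 cells (Homo sapiens) for inhibition, read by MTT assay, with a stated time of 72 h (on this read-out lower numbers stand for stronger inhibition and higher numbers for weaker inhibition), compound 1 `CN1CCN(c2cc(C(F)(F)F)nc(SCc3ccc(C(F)(F)F)cc3)n2)CC1` gives 15800 nM. Compound 3 `FC(F)(F)c1ccc(CSc2nc(Sc3nnnn3-c3ccccc3)cc(C(F)(F)F)n2)cc1`, at 12400 nM, lies within the scatter of compound 1. Compound 2 `FC(F)(F)c1ccc(CSc2nc(N3CCN(c4ccccc4)CC3)cc(C(F)(F)F)n2)cc1` reads 35200 nM, and a 2.2-fold higher number from compound 1 to compound 2 (0.35 log units; beyond the scatter) is a modest step beyond the scatter.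

Compound 4 `FC(F)(F)c1ccc(CSc2nc(Sc3nncs3)cc(C(F)(F)F)n2)cc1` differs from compound 1 by (1,3,4-thiadiazol-2-yl)sulfanyl in place of 4-methylpiperazin-1-yl on an aromatic carbon.

Within the data shown here, the one measured step, a 2.2-fold higher number from compound 1 to compound 2 (0.35 log units; beyond the scatter), changes only the group on the ring amine, so it bears on this swap only loosely. A closer guide is compound 3 at 12400 nM, which also carries a five-membered aromatic ring through sulfur.

In this assay the estimated step is a 1.1-fold lower number from compound 1 to compound 4 (0.05 log units; within the scatter), with none expected beyond the scatter. Compound 4 is expected at 14000 nM, within an estimated range of 6500 nM to 30000 nM.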

Compound 4, half-maximal inhibitory concentration: 10900 nM
Estimate against measurement, compound 4: 1.3-fold (0.11 log units) above, within the range that was stated.
By their numbers in this assay, from the lowest: compounds 4, 3 and 1 (each within the scatter of the next); then compound 2.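

Across this position, a 1.4-fold lower number from compound 1 to compound 4 (0.16 log units; within the scatter), so in this assay (1,3,4-thiadiazol-2-yl)sulfanyl cannot be told apart from 4-methylpiperazin-1-yl. On the sulfur, a 1.1-fold lower number from compound 3 to compound 4 (0.06 log units; within the scatter), so exchanging 1-phenyl-1H-tetrazol-5-yl for 1,3,4-thiadiazol-2-yl also gives no readable change. Nothing at hand accounts for these readings.

Still open, as far as these compounds go, is whether a primary amine or a carboxylic acid on a short chain at this position would move the number beyond the scatter. Also open, from the compounds shown here alone, is whether any sulfur-linked ring separates from compound 1.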